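A few compounds are considered here, and "the series" means these few. Any claim that something is new, unique, unknown or untested is made for them only; others in the source may bear on it.

In a physicochemical assay for solubility (a higher number here means a more soluble compound, a lower number a less soluble compound), compound 1, `CNC(=O)c1cc(C(=O)NC2CCOCC2)n([C@@H](C)c2ccccc2)n1`, gives 31 ug/mL. Compound 2, `CNC(=O)c1cc(C(=O)N[C@H]2CC[C@H](O)CC2)n([C@@H](C)c2ccccc2)n1`, is reported in this assay only as a limit of the assay, >= 180 ug/mL. Compound 3, `CNC(=O)c1cc(C(=O)N[C@H]2CC[C@H](OC)CC2)c([C@@H](C)c2ccccc2)o1`, likewise reaches a limit in this assay, >= 192 ug/mL. The single measured step on the same amide-type nitrogen is an at least 5.8-fold higher number from compound 1 to compound 2 (0.76 log units; beyond the scatter), so compound 2 stands at the upper end of the numbers shown, at a limit rather than a number. Compound 4, `CNC(=O)c1cc(C(=O)NCCO)n([C@@H](C)c2ccccc2)n1`, differs from compound 2 in that (2-hydroxyethyl in place of 4-hydroxycyclohexyl on an amide-type nitrogen). Going by the values given here, no measured step shares this exact change, so the expectation rests on compound 2 alone. Compound 4 is expected to remain at the limit, the estimated step being a step that the limit leaves unreadable from compound 2 to compound 4, with an estimate of 200 ug/mL, between 80 ug/mL and 450 ug/mL.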

Compound 4, solubility: >= 139 ug/mL
Compound 4 was reported as a limit; the forecaster's own chance of this, stated with the estimate: 60%; the middle value does not contradict the limit.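

On the amide-type nitrogen, 2-hydroxyethyl, which has no ring, gives in this assay an at least 4.4-fold higher number from compound 1 to compound 4 (0.65 log units; beyond the scatter), so the higher read-out over oxan-4-yl seen with 4-hydroxycyclohexyl does not require a six-membered ring at this place. Compound 4 is reported only as a limit of the assay: the limit of >= 139 ug/mL in this assay, at which 1 of the 4 values shown sits. The step between compound 2 and compound 4 cannot be read, which leaves 2-hydroxyethyl and 4-hydroxycyclohexyl unranked. As far as these compounds go, how far compound 2 and compound 4 lie past their limits stays open. So does how a longer chain such as 3-hydroxypropyl, or a chain ending in an amine, would read at this nitrogen.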